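A Lactam Swap on Compound 1

The source may hold more compounds than are shown below. What is called first, only, known or untested is meant among the compounds shown, and "the series" means these compounds.

Compound 1 `COc1ccc(N2CCc3c(-n4ccc(N5CCN(C)C5=O)n4)cc(C)nc32)c(C)c1` stands highest of the two numbers in an assay on CHO cells for displacement of a labelled ligand from corticotropin-releasing factor receptor 1 (Homo sapiens) (a lower number here means a stronger inhibitor, a higher number a weaker inhibitor), where compound 1 gives 794 nM. Compound 2 `Cc1cc(-n2ccc(N3CCNC3=O)n2)c2c(n1)N(c1ccc(C#N)cc1C)CC2` gives 67.6 nM in this assay, a gap beyond the scatter. Compound 3 `COc1ccc(N2CCc3c(-n4ccc(N5CCCC5=O)n4)cc(C)nc32)c(C)c1` differs from compound 1 in a single place: 2-oxopyrrolidin-1-yl in place of 3-methyl-2-oxoimidazolidin-1-yl on an aromatic carbon. Both groups sit on the same aromatic carbon of the five-membered aromatic ring with 2 nitrogen. For the measured compounds named here, no measured pair shows this change, so the expected step is a 1.2-fold lower number from compound 1 to compound 3 (0.09 log units; within the scatter), most likely none beyond the scatter. Compound 3 is therefore estimated at 650 nM in this assay, with a range from 200 nM to 2200 nM.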

Compound 3, half-maximal inhibitory concentration: 123 nM
The estimate for compound 3 lay 5.3-fold (0.72 log units) above the measured number; the whole stated range lies above it.
By their numbers in this assay, from the lowest: compounds 2 and 3 (each within the scatter of the next); then compound 1.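

this assay shows a 6.5-fold lower number from compound 1 to compound 3 (0.81 log units; beyond the scatter) when 2-oxopyrrolidin-1-yl replaces 3-methyl-2-oxoimidazolidin-1-yl on this aromatic carbon, so the position distinguishes between these two closely related rings. The change removes one ring hetero atom and leaves the counts of hydrogen-bond donors and acceptors the same, so those counts do not separate the two groups. No measurement accompanies the step that would account for it.

From the compounds shown here alone, whether 2-oxopiperidin-1-yl or an open-chain acetamido group would be tolerated on this carbon remains open. The compounds shown also leave open whether the same swap would give a similar step on another core.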